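Series notes: ester and side-chain changes on a shared core

The source may hold more compounds than are shown below. What is called first, only, known or untested is meant among the compounds shown, and "the series" means these compounds.

Three compounds have numbers in a functional assay on the whole organism (Tail, strain ICR) with Mus musculus as the target, in the tail flick test, with a stated time of 90 min, at a dose of 25 umol/kg by the oral route; on this read-out lower numbers stand for a weaker effect and higher numbers for a stronger effect at the one dose given. Compound 1 `C[C@H](NC(=O)CN(c1nc(Cl)nc2[nH]cnc12)C1CC1)C(=O)O` gives 43.5%. Compound 2 `CC[C@H](C)[C@H](NC(=O)CN(c1nc(Cl)nc2[nH]cnc12)C1CC1)C(=O)OCc1ccccc1` gives 36.3%, and compound 3 `C[C@H](NC(=O)CN(c1ncnc2c1ncn2C1CCCCO1)C1CC1)C(=O)OCc1ccccc1` gives 32.1%. The number of compound 2 lies between the other two, and both gaps are within the usual scatter, so no ordering among the three is secure.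

Compound 4 `NC(=O)C[C@H](NC(=O)CN(c1nc(Cl)nc2[nH]cnc12)C1CC1)C(=O)OCc1ccccc1` is not yet measured. It differs from compound 2 by carbamoylmethyl in place of sec-butyl on a saturated chain carbon bound to an amide-type nitrogen and a carbonyl carbon. Among the compounds with values here, no pairwise step between measured compounds is available, and the three numbers sit close together, so no step beyond the scatter is expected in this assay in either direction. The estimated step from compound 2 to compound 4 is a number 2.3 percentage points lower from compound 2 to compound 4 (within the scatter). Compound 4 is expected to give 34%, estimated within 20% to 48%.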

Compound 4, a percentage reported as activity, at one dose (the size of the read-out at that dose, not a potency): 32.3%
Compound 4: the middle estimate sits 1.7 percentage points above what was measured, and the stated range covers the measured number.
By their numbers in this assay, from the lowest: compounds 3, 4, 2 and 1 (each within the scatter of the next, the first and the last beyond it).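

In this assay, within the data shown here, carbamoylmethyl in place of sec-butyl on a saturated chain carbon bound to an amide-type nitrogen and a carbonyl carbon gives the first step that can be read (a number 4 percentage points lower from compound 2 to compound 4 (within the scatter)). At this position, exchanging a group with no hydrogen-bond donor or acceptor for one with one of each does not move the read-out beyond the scatter. Nothing on hand explains the step.

Every other pair differs in more than one place, so those steps cannot be read. From the compounds shown here alone, whether an aminobutyl chain or a phenyl ring on this carbon would give a step beyond the scatter remains open.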